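Extending the Alkyl Group on the Ring Nitrogen

The compounds below may be only part of what the source reports. "The series", "measured", "known", "first", "only" and "open" are said of these compounds alone.

Of the compounds shown here, two have been measured so far. Compound 1 `Cn1ncnc1-c1ccccc1NCC1=NCCN1` and compound 2 `Cn1ccc(-c2ccccc2NCC2=NCCN2)n1` share the same core and differ only in the ring carried on its aromatic carbon. In an in vitro functional assay on cells (Fibroblast) for agonist activity at Alpha-1B adrenergic receptor (Homo sapiens) (on this read-out higher numbers stand for an effect only at larger amounts of compound and lower numbers for an effect already at smaller amounts), compound 1 gives 39.8 nM, and compound 2 gives 50.1 nM. Going by the values given here, the single measured step, a 1.3-fold higher number from compound 1 to compound 2 (0.10 log units; within the scatter), describes the exchange of one small ring for another. Compound 2 therefore sits at one end of the two numbers shown, its only neighbour being compound 1, separated from it by a gap that falls within the scatter, so no order between the two can be read from these data.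

Compound 3 `CCn1ccc(-c2ccccc2NCC2=NCCN2)n1` differs from compound 2 by methyl in place of hydrogen on a saturated chain carbon bound to an aromatic nitrogen. Among the compounds with values here, no measured step touches this group: the step of a 1.3-fold higher number from compound 1 to compound 2 (0.10 log units; within the scatter) concerns the ring itself, not the alkyl group on its nitrogen, and it was itself within the scatter. On this basis the expectation for compound 3 in this assay is a step of a 1.3-fold higher number from compound 2 to compound 3 (0.10 log units; within the scatter), which is no change beyond the scatter, with no direction preferred. Compound 3 is estimated at 63 nM, with a range from 25 nM to 160 nM.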

Compound 3, half-maximal effective concentration: < 100000 nM
Compound 3 gave a limit, no number; the forecaster's own chance of this, stated with the estimate: 3%; the middle value lies beyond the limit too.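

In this assay compound 3 gives < 100000 nM, which is a limit of the assay and not a number. Going by these compounds alone, no step from compound 2 to compound 3 can therefore be read. The compounds shown leave open whether methyl in place of hydrogen on a saturated chain carbon bound to an aromatic nitrogen changes the value in this assay, and by how much.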